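A few compounds are considered here, and "the series" means these few. Any claim that something is new, unique, unknown or untested is made for them only; others in the source may bear on it.

Measured in a functional assay on LNCaP cells (Homo sapiens) for antiproliferative activity, read by WST assay, with a stated time of 3 days; a lower number here means a stronger inhibitor, a higher number a weaker inhibitor:
- compound 1 `CCOc1c(-c2cc(OC)c(OC)c(OC)c2)oc2ccccc2c1=O`: 5400 nM
- compound 2 `CCN(CC)CCCCOc1c(-c2cc(OC)c(OC)c(OC)c2)oc2ccccc2c1=O`: 13500 nM

Compound 2 has the higher of the two numbers in this assay. Compound 3 `CCN(CC)CCCCCOc1c(-c2cc(OC)c(OC)c(OC)c2)oc2ccccc2c1=O` differs from it by (diethylamino)methyl in place of diethylamino on a saturated chain carbon, four bonds along the chain from an oxygen on an aromatic ring. Among the compounds with values here, only one measured step bears on this: a 2.5-fold higher number from compound 1 to compound 2 (0.40 log units; beyond the scatter), a modest one that adds the amine chain rather than lengthening it. Within the data shown here, no measured step shows the effect of chain length, so no change beyond the scatter is expected in this assay. The expected step is a 1.4-fold lower number from compound 2 to compound 3 (0.13 log units; within the scatter). For compound 3 the estimate is 10000 nM, with an expected range of 4000 nM to 24000 nM.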

Compound 3, half-maximal inhibitory concentration: 10000 nM
Estimate against measurement, compound 3: no gap at the digits printed; measured number inside the range.
By their numbers in this assay, from the lowest: compounds 1, 3 and 2 (each within the scatter of the next, the first and the last beyond it).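

Replacing diethylamino with (diethylamino)methyl on the saturated chain carbon gives a 1.4-fold lower number from compound 2 to compound 3 (0.13 log units; within the scatter) in this assay, so this lengthening of the chain leaves the number within the scatter. Set against the shared core's simple ether, 3-(diethylamino)propyl in place of hydrogen gives a 1.9-fold higher number from compound 1 to compound 3 (0.27 log units; within the scatter), so with this longer chain the amine compound no longer stands apart from compound 1 beyond the scatter. Nothing measured on these compounds accounts for this. Still open, from the compounds shown here alone, is whether a longer chain, or a cyclic amine such as piperidine at its end, would change the number beyond the scatter.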